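HEL Cytotoxicity: Pyrrolyl Replaced by Chlorophenylsulfanyl

The source may hold more compounds than are shown below. What is called first, only, known or untested is meant among the compounds shown, and "the series" means these compounds.

Compound 1, `C=Cc1ccc(-c2cc(C)c3ncc(CSCCc4ccccc4)n3c2)cc1`: 20 ug/mL
Compound 2, `Cc1cc(-c2ccc(C=O)cc2)cn2c(CSCCc3ccccc3)cnc12`: 100 ug/mL
Compound 3, `Cc1cc(-n2cccc2)cn2c(CSCCc3ccccc3)cnc12`: >= 4 ug/mL

In an ADME assay on HEL cells (Homo sapiens) for cytotoxicity, with a stated time of 3 days (on this read-out higher numbers stand for lower toxicity in this test and lower numbers for higher toxicity in this test), compound 1 gives 20 ug/mL and compound 2 gives 100 ug/mL, a shift of a 5.0-fold higher number from compound 1 to compound 2 (0.70 log units; beyond the scatter). For compound 3 the assay reports only a limit, >= 4 ug/mL. Its standing among the three therefore cannot be read, and the steps a step that the limit leaves unreadable from compound 1 to compound 3 and a step that the limit leaves unreadable from compound 2 to compound 3 remain unreadable because of the limit of >= 4 ug/mL in this assay, at which 1 of the 3 values shown sits. Compound 4, `Cc1cc(Sc2ccc(Cl)cc2)cn2c(CSCCc3ccccc3)cnc12`, differs from compound 3 by (4-chlorophenyl)sulfanyl in place of 1H-pyrrol-1-yl on an aromatic carbon. Going by the values given here, no measured step covers this change, and the starting point is a limit, so no direction beyond the scatter can be argued. The value of compound 4 is expected near 20 ug/mL, within 4 ug/mL to 100 ug/mL. That estimate means an expected step that the limit leaves unreadable from compound 3 to compound 4.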

Compound 4, minimum cytotoxic concentration: 20 ug/mL
Compound 4: the middle estimate sits on the measured number at the digits printed, within the range that was stated.
By their numbers in this assay, from the lowest: compounds 1 and 4 (each within the scatter of the next); then compound 2.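

Placing (4-chlorophenyl)sulfanyl on this aromatic carbon gives no change at the digits printed from compound 1 to compound 4 (within the scatter), so in this assay a ring joined through sulfur reads the same as 4-vinylphenyl. Set against 4-formylphenyl, the same change gives a 5.0-fold lower number from compound 2 to compound 4 (0.70 log units; beyond the scatter), which leaves compound 2 alone with the higher number. Compound 3 carries only a limit, and its steps, including the one to compound 4, cannot be read: the limit of >= 4 ug/mL in this assay, at which 1 of the 4 values shown sits.

Still open, as far as these compounds go, is whether the sulfur link itself matters, and how an amine or a carboxylic acid in place of the chlorine would read.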